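Replacing an Imidazole with a Methylthiazole: an Expected Return

The compounds below may be only part of what the source reports. "The series", "measured", "known", "first", "only" and "open" are said of these compounds alone.

Compound 3, `c1ccc(-c2ncc[nH]2)c(OCC2=NCCN2)c1`, carries a 1H-imidazol-2-yl group on the shared core. In a functional assay for activation of Alpha-1B adrenergic receptor (Homo sapiens), read by calcium flux (on this read-out higher numbers stand for an effect only at larger amounts of compound and lower numbers for an effect already at smaller amounts), compound 3 gives < 100000 nM, which is a limit of the assay and not a number. Its two neighbours are measured outright: compound 1, `c1ccc(-c2ccoc2)c(OCC2=NCCN2)c1`, gives 5.01 nM in this assay, and compound 2, `c1ccc(-c2ccns2)c(OCC2=NCCN2)c1`, gives 12.6 nM. The change from compound 1 to compound 2 amounts to a 2.5-fold higher number from compound 1 to compound 2 (0.40 log units; beyond the scatter). The changes to compound 3 are a step that the limit leaves unreadable from compound 1 to compound 3 and a step that the limit leaves unreadable from compound 2 to compound 3, and the reason is the limit of < 100000 nM in this assay, at which 1 of the 3 values shown sits.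

Compound 4, `Cc1csc(-c2ccccc2OCC2=NCCN2)n1`, is not yet measured and differs from compound 3 by 4-methyl-1,3-thiazol-2-yl in place of 1H-imidazol-2-yl on an aromatic carbon. Going by the values given here, no measured step carries a 1,3-thiazol-2-yl group, so the guidance comes from compound 1 and compound 2, both of which carry a five-membered ring without a hydrogen-bond donor and both of which sit in the single-digit to low double-digit range of this assay. Compound 4 is therefore expected to lie near them, with a step that the limit leaves unreadable from compound 3 to compound 4 expected from the limit of compound 3 that the assay cannot size. Compound 4 is estimated at 15 nM in this assay, with a range from 3 nM to 80 nM.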

Compound 4, half-maximal effective concentration: < 100000 nM
Compound 4: a limit, no number (the forecaster's own chance of this, stated with the estimate: 10%); the middle value lies beyond the limit too.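

In this assay compound 4 gives < 100000 nM, which is a limit of the assay and not a number. The steps from compound 1, compound 2 and compound 3 to compound 4 therefore cannot be read, because the comparison ends at the limit: the limit of < 100000 nM in this assay, at which 2 of the 4 values shown sit. The compounds shown leave open whether compound 3 and compound 4 differ from each other at all.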